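This account rests on a few compounds, and the source may have more. Where it says the series, first, only, none or still open, it means among the compounds named here.

Measured in an ADME assay on a cell-free system (plasma, Rattus norvegicus) for metabolic stability, read by LC-MS, with a stated time of 60 min, tested at 100 uM; on this read-out higher numbers stand for a more stable compound and lower numbers for a less stable compound:
- compound 1 `Cc1c(OCCCCOCOc2ccc(C(=O)O)cc2)ccc(C(=O)CC2CCCC2)c1O`: 100%
- compound 2 `Cc1c(OCCCCOc2ccc(C(=O)O)cc2F)ccc(C(=O)CC2CCCC2)c1O`: 97%
- compound 3 `CCCC(=O)c1ccc(OCCCCOc2cc(C(=O)O)ccc2OC)c(C)c1O`: 78%

In this assay, compound 3, at 78%, is the lowest of the three and lies beyond the scatter from both others. Compound 4 `COc1ccc(C(=O)O)cc1OCCCCOc1ccc(C(=O)CC2CCCC2)c(O)c1C` differs from it by one change: cyclopentyl in place of ethyl on a saturated chain carbon bound to a carbonyl carbon. Among the compounds with values here, no measured step covers this change. Within the data shown here, the only step available, a number 3 percentage points lower from compound 1 to compound 2 (within the scatter), concerns a different change elsewhere in the molecule, so it bears on this one only indirectly. Still, compound 1 and compound 2 both carry the cyclopentyl at that chain carbon, with compound 1 reading 100% and compound 2 reading 97%, though they also differ from compound 3 in other places. A modest rise is therefore expected, about the size of the scatter. The expected step is a number 9 percentage points higher from compound 3 to compound 4 (within the scatter). For compound 4 the estimated value is 87%, with an expected range of 74% to 100%.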

Compound 4, percent of the compound remaining: 103%
Beside the measured number, compound 4's estimate is 16 percentage points below it, outside the stated range (above it).
By their numbers in this assay, from the lowest: compound 3; then compounds 2, 1 and 4 (each within the scatter of the next).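

In this assay, within the data shown here, cyclopentyl in place of ethyl on a saturated chain carbon bound to a carbonyl carbon gives a number 25 percentage points higher from compound 3 to compound 4 (beyond the scatter), the first direct reading of this change, since the earlier compounds carrying cyclopentyl also differed in other places. With cyclopentyl kept, 5-carboxy-2-methoxyphenyl in place of 4-carboxy-2-fluorophenyl on an oxygen on a saturated carbon gives a number 6 percentage points higher from compound 2 to compound 4 (within the scatter), and the same group in place of (4-carboxyphenoxy)methyl gives a number 3 percentage points higher from compound 1 to compound 4 (within the scatter), so among these compounds the read-out separates at the chain carbon and not at the oxygen. Nothing shown accounts for the size of the step at the chain carbon.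

The compounds shown leave open whether a cyclohexyl, a phenyl or a longer chain at this chain carbon would read like cyclopentyl or like ethyl. They also leave open whether the step from ethyl to cyclopentyl would be the same with 4-carboxy-2-fluorophenyl on the oxygen.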